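Cyclic disulfide to thiosulfinate swap on two sugar cores

The source may hold more compounds than are shown below. What is called first, only, known or untested is meant among the compounds shown, and "the series" means these compounds.

Values in a functional assay on HeLa cells (Homo sapiens) for cytotoxicity, read by MTT assay, in the presence of a further agent that is not named here; a lower number here means a stronger inhibitor, a higher number a weaker inhibitor:
compound 1 `CC1(C)O[C@H]([C@H]2COC(C)(C)O2)[C@@H](C2CC(=O)SS2)O1`: 16900 nM
compound 2 `CC1(C)O[C@H]([C@H]2COC(C)(C)O2)[C@@H](C2CC(=O)S[S+]2[O-])O1`: 12600 nM
compound 3 `Cc1cn([C@H]2C[C@H](O)[C@@H](C3CC(=O)SS3)O2)c(=O)[nH]c1=O`: 54600 nM

Compounds 1 and 2 share a core and differ by a group of 7 heavy atoms (3 carbon, 2 oxygen, 2 sulfur; one five-membered non-aromatic ring with 2 hetero atoms) in place of a group of 6 heavy atoms (3 carbon, 1 oxygen, 2 sulfur; one five-membered non-aromatic ring with 2 hetero atoms), on a saturated ring carbon; the step is a 1.3-fold lower number from compound 1 to compound 2 (0.13 log units; within the scatter). Compound 3 gives the highest number of the three; how its core differs from that of compound 1 is not broken down here.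

Compound 4 `Cc1cn([C@H]2C[C@H](O)[C@@H](C3CC(=O)S[S+]3[O-])O2)c(=O)[nH]c1=O` has not been measured. It differs from compound 3 by a group of 7 heavy atoms (3 carbon, 2 oxygen, 2 sulfur; one five-membered non-aromatic ring with 2 hetero atoms) in place of a group of 6 heavy atoms (3 carbon, 1 oxygen, 2 sulfur; one five-membered non-aromatic ring with 2 hetero atoms), on a saturated ring carbon. This is the same kind of change as that from compound 1 to compound 2, but the surroundings differ: in compound 3 the saturated ring carbon sits in a five-membered non-aromatic ring with 1 oxygen, next to the ring atom that bears a hydroxy group, whereas in compound 1 it sits in a ring with 2 oxygen, next to the ring atom that bears a group of 7 heavy atoms and two ring bonds from the ring atom that bears two methyl groups.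

A step of a 1.3-fold lower number from compound 3 to compound 4 (0.11 log units; within the scatter) is expected for compound 4, because a 1.3-fold lower number from compound 1 to compound 2 (0.13 log units; within the scatter) shows the same kind of change leaving the number essentially unchanged. Compound 4 is therefore estimated at 42000 nM, with an expected range from 20000 nM to 90000 nM.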

Compound 4, half-maximal inhibitory concentration: 29700 nM
For compound 4 the middle estimate is 1.4-fold (0.15 log units) above the measured one, and the stated range covers the measured number.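

In this assay, the swap of the cyclic disulfide for the thiosulfinate on the second core gives a 1.8-fold lower number from compound 3 to compound 4 (0.26 log units; within the scatter). Set beside the earlier step, the change shows no detectable dependence on the core: the same change on two cores in this assay, a 1.3-fold lower number (0.13 log units; within the scatter) from compound 1 to compound 2 and a 1.8-fold lower number (0.26 log units; within the scatter) from compound 3 to compound 4, 1.4-fold (0.14 log units) apart, within the scatter of two such steps

This supports treating the swap as leaving the number essentially unchanged on the cores of compound 1 and compound 3, but with both steps inside the scatter it shows no real gain from the swap, and two cores give no basis for a rule across the wider series.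

Still open, on these data alone, is whether the step stays this small on a core that carries an amine, a carboxylic acid or a longer chain. Also open, as far as these compounds go, is whether the swap behaves the same way in any read-out other than this assay.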